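Moving the nitrile: from compound 2 to compound 3

A few compounds are considered here, and "the series" means these few. Any claim that something is new, unique, unknown or untested is made for them only; others in the source may bear on it.

Of the compounds shown here, two have been measured in a functional assay (muscle tissue) with Cavia porcellus as the target; a lower number here means that less compound is needed, a higher number that more compound is needed for the effect. Compound 1 `COC(=O)C1=C(C)N=C(C)/C(=C(\O)OC)C1c1ccccc1C#N` gives 15.9 nM. Among the compounds with values here, compound 2 `COC(=O)C1=C(C)N=C(C)/C(=C(\O)OC)C1c1ccccc1F` gives 42.7 nM, which is the highest of the two numbers, and the only step known so far, a 2.7-fold higher number from compound 1 to compound 2 (0.43 log units; beyond the scatter), joins it to compound 1.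

Compound 3 `COC(=O)C1=C(C)N=C(C)/C(=C(\O)OC)C1c1ccc(C#N)cc1` has not been measured yet. Compared with compound 2 the change is 4-cyanophenyl in place of 2-fluorophenyl on a saturated ring carbon.

Within the data shown here, only the step from compound 1 to compound 2 bears on this change, since it also exchanges a nitrile for a fluorine on the aromatic ring and went the other way, a 2.7-fold higher number from compound 1 to compound 2 (0.43 log units; beyond the scatter). Compound 1 does not carry 4-cyanophenyl, however, so that step is an incomplete guide and the expectation carries wide limits. The return of a nitrile is expected to give a modestly lower number for compound 3 in this assay, around 25 nM, within a range from 6 nM to 100 nM, that is a step of a 1.7-fold lower number from compound 2 to compound 3 (0.23 log units; within the scatter).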

Compound 3, half-maximal effective concentration: 3470 nM
Beside the measured number, compound 3's estimate is 140-fold (2.14 log units) below it; measured number above the stated range.
By their numbers in this assay, from the lowest: compound 1; then compound 2; then compound 3.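

In this assay, the presence of a nitrile does not by itself give a low number, since 2-cyanophenyl and 4-cyanophenyl carry the same groups and differ only in where the nitrile sits on the phenyl ring, yet that difference produces a 220-fold higher number from compound 1 to compound 3 (2.34 log units; beyond the scatter). Exchanging 2-fluorophenyl for 4-cyanophenyl also gives a large change, an 81-fold higher number from compound 2 to compound 3 (1.91 log units; beyond the scatter), whereas exchanging nitrile for fluorine within the 2-substituted pair gave only a 2.7-fold higher number from compound 1 to compound 2 (0.43 log units; beyond the scatter), so among these three compounds the place of the group on the phenyl ring matters far more than the choice between those two groups. Nothing measured here accounts for the size of these steps.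

The compounds shown leave open whether the high number of compound 3 belongs to the nitrile itself or would follow any group placed as in 4-cyanophenyl, and a fluorine, a methoxy group or an amine at that place would tell these apart. Also open, as far as these compounds go, is how a plain phenyl ring, with no group on it, would compare with 2-cyanophenyl and 4-cyanophenyl.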